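The source may hold more compounds than are shown below. What is called first, only, known or untested is meant among the compounds shown, and "the series" means these compounds.

Measured so far:
- compound 1 `O=C1C[C@H](OCc2cn(-c3ccccc3Cl)nn2)[C@H]2CO[C@@H]1O2`: 26400 nM
- compound 2 `O=C1C[C@H](OCc2cc(-c3ccccc3)no2)[C@H]2CO[C@@H]1O2`: 21900 nM

In a functional assay on MDA-MB-231 cells (Homo sapiens) for cytotoxicity, read by MTT assay, with a stated time of 48 h (a lower number here means a stronger inhibitor, a higher number a weaker inhibitor), compound 2 gives 21900 nM, the lowest of the two numbers, while compound 1 gives 26400 nM, a gap that lies within the scatter. Compound 3 `O=C1C[C@H](OCc2cc(-c3ccc([N+](=O)[O-])cc3)no2)[C@H]2CO[C@@H]1O2` differs from compound 2 by nitro in place of hydrogen on an aromatic carbon. Going by the values given here, no pair of measured compounds shows this change, so nothing indicates its direction; the two values at hand are both weak and close, and no step beyond the scatter is expected. Compound 3 is therefore estimated at 18000 nM, between 7000 nM and 45000 nM, an expected step of a 1.2-fold lower number from compound 2 to compound 3 (0.09 log units; within the scatter).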

Compound 3, half-maximal inhibitory concentration: 16500 nM
The estimate for compound 3 lay 1.1-fold (0.04 log units) above the measured number; low and high end bracket the measured number.
By their numbers in this assay, from the lowest: compounds 3, 2 and 1 (each within the scatter of the next).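

In this assay, nitro in place of hydrogen on an aromatic carbon, para to a large group, gives a 1.3-fold lower number from compound 2 to compound 3 (0.12 log units; within the scatter). This is the first change in one place among these compounds, and it shows that this position carries nitro, with its three heavy atoms, without a step beyond the scatter. No evidence at hand bears on this result. The compounds shown leave open whether an amine or a carboxylic acid at this same position would give a step beyond the scatter.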